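The source may hold more compounds than are shown below. What is called first, only, known or untested is meant among the compounds shown, and "the series" means these compounds.

Series notes. Compound 1 `CCOC(=O)[C@H](CCC(=O)O)NC(=O)c1ccc(Sc2nc3cc(N)cc(N)c3nc2-c2ccccc2)cc1` is reported in a functional assay on NCI-H460 cells (Homo sapiens) for inhibition, read by sulforhodamine B assay, with a stated time of 48 h (on this read-out higher numbers stand for weaker inhibition of growth and lower numbers for stronger inhibition of growth), only as a limit, < 100000 nM. Compound 3 `COc1cc(CNc2nc3cc(N)cc(N)c3nc2-c2ccccc2)cc(OC)c1OC` likewise gives only a limit, < 50200 nM. Among the compounds with values here, compound 2 `Nc1cc(N)c2nc(-c3ccccc3)c(Sc3ccc(F)cc3)nc2c1` is the one member with a number: in this assay compound 2 gives 66100 nM. The two other values stand as limits (the limit of < 100000 nM in this assay, at which 1 of the 3 values shown sits, (the limit of < 50200 nM in this assay, at which 1 of the 3 values shown sits)). Within the data shown here, no pair of measured compounds differs in a single place, so no measured step is available for guidance. Compound 4 `Nc1cc(N)c2nc(-c3ccccc3)c(Sc3ccc(Cl)c(Cl)c3)nc2c1` is not yet measured; it differs from compound 2 by 3,4-dichlorophenyl in place of 4-fluorophenyl on a sulfur. Among the measured compounds shown here, with no comparable step to draw on, only a small shift is expected in this assay, if anything towards stronger inhibition of growth, as a step of a 1.7-fold lower number from compound 2 to compound 4 (0.22 log units; within the scatter). Compound 4 is expected to give 40000 nM, within 15000 nM to 100000 nM.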

Compound 4, concentration for total growth inhibition: 33900 nM
Beside the measured number, compound 4's estimate is 1.2-fold (0.07 log units) above it; the measured number falls inside the stated range.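

Within the data shown here, this is the first single-place comparison: in this assay, 3,4-dichlorophenyl in place of 4-fluorophenyl on a sulfur gives a 1.9-fold lower number from compound 2 to compound 4 (0.29 log units; within the scatter). The aryl group on this sulfur can therefore carry either halogen pattern with no change beyond the scatter. No measured evidence here bears on a cause for this step.

Still open, going by these compounds, is whether a different group on the sulfur, such as a straight hexyl chain or a phenyl ring bearing a primary amine, would move the number beyond the scatter. On these data alone, the effect of changing the phenyl on the shared core also remains open.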